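Cathepsin S ureas: P2 side-chain swaps

A few compounds are considered here, and "the series" means these few. Any claim that something is new, unique, unknown or untested is made for them only; others in the source may bear on it.

Measured so far:
compound 1 `CC(C)C[C@H](NC(=O)N1CCOCC1)C(=O)N[C@H](C#N)CCc1ccccc1` — 7 nM
compound 2 `CC(C)C[C@H](NC(=O)N1CCOCC1)C(=O)N[C@H](C#N)COCc1ccccc1Cl` — 0.3 nM
compound 3 `N#C[C@H](CCc1ccccc1)NC(=O)[C@@H](NC(=O)N1CCOCC1)C1CCCCC1` — 5 nM

In an assay on isolated protein for displacement of a labelled ligand from cathepsin S (Homo sapiens), read by fluorescence (on this read-out lower numbers stand for tighter binding and higher numbers for weaker binding), compound 3 stands second highest of the three numbers; its nearest neighbour is compound 1, and the step of a 1.4-fold lower number from compound 1 to compound 3 (0.15 log units; within the scatter) lies within the scatter. Its furthest neighbour is compound 2, which sits well apart, the step of a 23-fold lower number from compound 1 to compound 2 (1.37 log units; beyond the scatter) being large.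

Compound 4 `CC(C)(C)C[C@H](NC(=O)N1CCOCC1)C(=O)N[C@H](C#N)CCc1ccccc1` has not yet been measured. The change is neopentyl in place of cyclohexyl on a saturated chain carbon bound to an amide-type nitrogen and a carbonyl carbon. Going by the values given here, the only measured step at this place is a 1.4-fold lower number from compound 1 to compound 3 (0.15 log units; within the scatter), a small exchange of one saturated side chain for another, and it stayed within the scatter. The large step of a 23-fold lower number from compound 1 to compound 2 (1.37 log units; beyond the scatter) concerns a different place and does not bear on this change. For compound 4 in this assay a step of a 1.2-fold higher number from compound 3 to compound 4 (0.08 log units; within the scatter) is therefore expected, that is, no change beyond the scatter. Compound 4 is estimated at 6 nM, within a range of 2 nM to 20 nM.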

Compound 4, dissociation constant: 0.9 nM
Estimate against measurement, compound 4: 6.7-fold (0.82 log units) above; measured number outside the range, below it.
By their numbers in this assay, from the lowest: compound 2; then compound 4; then compounds 3 and 1 (each within the scatter of the next).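

In this assay the saturated side chain on the saturated chain carbon bound to an amide-type nitrogen and a carbonyl carbon is not freely exchangeable: neopentyl in place of cyclohexyl gives a 5.6-fold lower number from compound 3 to compound 4 (0.74 log units; beyond the scatter) and so lies beyond the scatter, unlike the earlier exchange at this place. Adding one methyl to the isobutyl group gives a 7.8-fold lower number from compound 1 to compound 4 (0.89 log units; beyond the scatter) and so separates neopentyl from isobutyl as well, although isobutyl and cyclohexyl remain within the scatter of each other. No measurement at hand bears on the reason for this difference.

From the compounds shown here alone, whether neopentyl gives a step of similar size on the core of compound 2, with its (2-chlorobenzyl)oxy group, remains open. Also open, going by these compounds, is how a longer chain or a side chain carrying an amine would behave at this place.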